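This account rests on a few compounds, and the source may have more. Where it says the series, first, only, none or still open, it means among the compounds named here.

Working notes on the series, step from compound 3 to compound 4.

The series shares the core seen in compound 2, `c1ccc2c(c1)CCC2c1ncc[nH]1`. In a functional assay on CHO cells for agonist activity at Alpha-1B adrenergic receptor (Homo sapiens), read by FLIPR and calcium flux (on this read-out higher numbers stand for an effect only at larger amounts of compound and lower numbers for an effect already at smaller amounts), compound 2 gives > 10000 nM, which is a limit of the assay and not a number. Compound 1, `c1cc(-c2cn[nH]c2)c2c(c1)C(c1ncc[nH]1)CC2`, carries a 1H-pyrazol-4-yl group on an aromatic carbon of that core. In this assay compound 1 gives > 10000 nM, again a limit of the assay. Compound 3, `c1cc(-c2ncco2)c2c(c1)C(c1ncc[nH]1)CC2`, carries a 1,3-oxazol-2-yl group at the same place. In this assay compound 3 gives > 10000 nM, also a limit of the assay, so compound 3 stands where every measured member stands (the limit of > 10000 nM in this assay, at which 3 of the 3 values shown sit).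

The steps a step that the two limits leave unreadable from compound 1 to compound 2, a step that the two limits leave unreadable from compound 1 to compound 3 and a step that the two limits leave unreadable from compound 2 to compound 3 are all unreadable, since both ends sit at the limit.

Compound 4, `COc1cccc2c1CCC2c1ncc[nH]1`, differs from compound 3 by methoxy in place of 1,3-oxazol-2-yl on an aromatic carbon. Within the data shown here, no measured step covers a methoxy, and none among the measured steps has a readable size, so no step in this assay can be read off; the only guidance is that every measured compound sits at the limit (the limit of > 10000 nM in this assay, at which 3 of the 3 values shown sit).

Compound 4 is therefore expected to remain near the limit, with an estimated value of 20000 nM, range 5000 nM to 100000 nM. The step from compound 3 is expected to be a step that the limit leaves unreadable from compound 3 to compound 4, most likely unreadable in this assay.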

Compound 4, half-maximal effective concentration: > 10000 nM
Compound 4 gave a limit, no number; the forecaster's own chance of this, stated with the estimate: 80%; the middle value lies beyond the limit too.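

In this assay compound 4 gives > 10000 nM as a limit of the assay, not a number. No new step can be read between compound 4 and compound 1, compound 2 or compound 3, since all four sit at the same limit: the limit of > 10000 nM in this assay, at which 4 of the 4 values shown sit.

The compounds shown leave open which change to the shared core, if any, would bring a number in this assay within reach of the assay.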